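The compounds below may be only part of what the source reports. "The series", "measured", "known", "first", "only" and "open" are said of these compounds alone.

Compound 1 `CC1=C(C(=O)Nc2ccc(F)cc2)C(c2ccc([N+](=O)[O-])cc2)N=C(SCc2ccccc2Cl)N1` gives 8.8% in a functional assay on the whole organism (artery, strain albino) with Rattus norvegicus as the target, with a stated time of 120 min, at a dose of 10 mg/kg by the oral route; a higher number here means more inhibition at the dose given (going by the name of the read-out), a lower number less inhibition. Compound 2 `CC1=C(C(=O)Nc2ccc(F)cc2)C(c2ccc([N+](=O)[O-])cc2)N=C(SCc2cccc(Cl)c2)N1`, which carries 3-chlorophenyl in place of 2-chlorophenyl on a saturated chain carbon bound to a sulfur, gives 9.8% in this assay, so that the change a number 1 percentage points higher from compound 1 to compound 2 (within the scatter). Compound 3 `CC1=C(C(=O)Nc2ccc([N+](=O)[O-])cc2)C(c2cccc([N+](=O)[O-])c2)N=C(SCc2ccccc2Cl)N1` differs from compound 1 in its core in a way that is not broken down here. In this assay compound 3 gives 7.7%, a value that lies within the scatter of both compound 1 and compound 2. Compound 4 `CC1=C(C(=O)Nc2ccc([N+](=O)[O-])cc2)C(c2cccc([N+](=O)[O-])c2)N=C(SCc2cccc(Cl)c2)N1` has not been measured; it differs from compound 3 by 3-chlorophenyl in place of 2-chlorophenyl on a saturated chain carbon bound to a sulfur, the same change made from compound 1 to compound 2. Because that earlier change gave a number 1 percentage points higher from compound 1 to compound 2 (within the scatter), the step expected in this assay is a number 0.8 percentage points higher from compound 3 to compound 4 (within the scatter). Compound 4 is therefore estimated to give 8.5% in this assay, with a range expected from 2% to 16%.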

Compound 4, a percentage reported as inhibition, in the whole organism at one dose (the size of the read-out at that dose, not a potency): 12.4%
Estimate against measurement, compound 4: 3.9 percentage points below, within the range that was stated.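

In this assay, 3-chlorophenyl in place of 2-chlorophenyl on a saturated chain carbon bound to a sulfur gives a number 4.7 percentage points higher from compound 3 to compound 4 (within the scatter). Set beside the earlier step, the result gives no sign that the core alters what this change does: the same change on two cores in this assay, a number 1 percentage points higher (within the scatter) from compound 1 to compound 2 and a number 4.7 percentage points higher (within the scatter) from compound 3 to compound 4, 3.7 percentage points apart, within the scatter of two such steps. Since each step lies within the scatter, the two cores do not show that the change raises inhibition on either one, and two cores cannot establish a rule for the series.

From the compounds shown here alone, it remains open whether a larger step would appear with a methoxy group or an amine in place of the chlorine, or with a longer chain on the sulfur. Behaviour at other doses also remains open.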